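Working notes on the step from compound 2 to compound 3

The source may hold more compounds than are shown below. What is called first, only, known or untested is meant among the compounds shown, and "the series" means these compounds.

Measured so far:
compound 1 `Cc1c(Cc2ccccc2)c(=O)oc2cc(OCC(O)CNCc3ccccc3)ccc12` — > 100000 nM (a limit of the assay)
compound 2 `Cc1c(Cc2ccc(Cl)cc2)c(=O)oc2cc(OCC(O)CN3CCC(C(N)=O)CC3)ccc12` — 40000 nM

Two compounds have been run in an ADME assay on A549 cells (Homo sapiens) for cytotoxicity, read by CellTiter-Glo; a lower number here means that less compound is tolerated, a higher number that more compound is tolerated. For compound 1 `Cc1c(Cc2ccccc2)c(=O)oc2cc(OCC(O)CNCc3ccccc3)ccc12` the read-out is a limit of the assay, > 100000 nM. Going by the values given here, compound 2 `Cc1c(Cc2ccc(Cl)cc2)c(=O)oc2cc(OCC(O)CN3CCC(C(N)=O)CC3)ccc12` gives 40000 nM in this assay and is the only compound in the set with an actual number. The other value shown is the limit of > 100000 nM in this assay, at which 1 of the 2 values shown sits. Among the compounds with values here, no step between two measured compounds exists here, so the set itself does not tell how a change on the benzyl-type arm moves the read-out.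

Compound 3 `COc1ccc(Cc2c(C)c3ccc(OCC(O)CN4CCC(C(N)=O)CC4)cc3oc2=O)c(Br)c1` differs from compound 2 by 2-bromo-4-methoxyphenyl in place of 4-chlorophenyl on a saturated chain carbon bound to an aromatic carbon; the rest of compound 2 is kept. Within the data shown here, with no measured step to lean on, the shift expected from compound 2 to compound 3 in this assay is none beyond the scatter, a 1.1-fold lower number from compound 2 to compound 3 (0.06 log units; within the scatter). Compound 3 is therefore expected to give about 35000 nM in this assay, with a range from 12000 nM to 100000 nM. The measured value for compound 3 follows.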

Compound 3, half-maximal cytotoxic concentration: 44400 nM
The estimate for compound 3 lay 1.3-fold (0.10 log units) below the measured number, and the stated range covers the measured number.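

In this assay, the piece now holds one readable step on this arm: a 1.1-fold higher number from compound 2 to compound 3 (0.05 log units; within the scatter). Compound 2 and compound 3 therefore cannot be told apart in this read-out, although 2-bromo-4-methoxyphenyl stands in place of 4-chlorophenyl on a saturated chain carbon bound to an aromatic carbon and brings 9 heavy atoms against 7, a bromine in place of the chlorine, and 1 hydrogen-bond acceptor against 0. Going by these compounds alone, the one line of supporting evidence concerns only how the values sit at the assay limit and does not bear on this result.

Compound 1 gives only a limit of the assay, > 100000 nM, and differs from compound 2 in more than one place, so it offers no readable step for either the arm or the side chain. On these data alone, still open in this assay is whether a carboxylic acid or an aminomethyl group on this phenyl ring, or a longer chain in place of the single saturated carbon, would shift the number beyond the scatter.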